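A Third Methoxy Group on the Saturated-Ring Aryl

The source may hold more compounds than are shown below. What is called first, only, known or untested is meant among the compounds shown, and "the series" means these compounds.

Compound 1 `Cc1cc(O)c(C2=NN(c3ccc(S(N)(=O)=O)cc3)C(c3ccccc3O)C2)cc1Cl` — 15300 nM
Compound 2 `COc1ccc(C2CC(c3cc(Cl)c(C)cc3O)=NN2c2ccc(S(N)(=O)=O)cc2)cc1OC` — 30000 nM

Both compounds share one core and were tested in a functional assay on SN12C cells (Homo sapiens) for antiproliferative activity, with a stated time of 48 h; a lower number here means a stronger inhibitor of growth, a higher number a weaker inhibitor of growth. Within the data shown here, compound 2 gives the higher of the two numbers, 30000 nM, but the only measured step, a 2.0-fold higher number from compound 1 to compound 2 (0.29 log units; within the scatter), lies within the scatter, so the two compounds cannot be ordered against each other.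

Compound 3 `COc1ccc(C2CC(c3cc(Cl)c(C)cc3O)=NN2c2ccc(S(N)(=O)=O)cc2)c(OC)c1OC` differs from compound 2 by methoxy in place of hydrogen on an aromatic carbon. Among the measured compounds shown here, no measured step adds a single methoxy group; the one step on record exchanges the whole aryl ring on the saturated carbon and shows no change beyond the scatter. On that basis no step beyond the scatter is expected in this assay, and the estimated step is no change at the digits printed from compound 2 to compound 3 (within the scatter). Compound 3 is therefore expected to give about 30000 nM, with a range from 12000 nM to 75000 nM.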

Compound 3, concentration for total growth inhibition: 10300 nM
Compound 3: the middle estimate sits 2.9-fold (0.46 log units) above what was measured; the measured number lies below the stated range.
By their numbers in this assay, from the lowest: compounds 3, 1 and 2 (each within the scatter of the next, the first and the last beyond it).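

In this assay, the change from 3,4-dimethoxyphenyl to 2,3,4-trimethoxyphenyl on the saturated ring carbon gives a 2.9-fold lower number from compound 2 to compound 3 (0.46 log units; beyond the scatter), the only step among these compounds that lies beyond the scatter, and a modest one. This shows that the number can respond to a single methoxy group on this aromatic carbon, yet the comparison with the 2-hydroxyphenyl ring gives a 1.5-fold lower number from compound 1 to compound 3 (0.17 log units; within the scatter), which is within the scatter, so those two compounds cannot be ordered. Nothing measured here accounts for the step.

The compounds shown leave open whether methoxy itself matters on this carbon, or whether an amine or a fluorine atom there would move the number the same way. They also leave open whether adding methoxy to the 2-hydroxyphenyl ring of compound 1 would give a comparable step.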